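The source may hold more compounds than are shown below. What is called first, only, known or untested is meant among the compounds shown, and "the series" means these compounds.

Measured compounds:
- compound 1, `Cc1ccccc1Cc1cnc(N)nc1N` — in an assay for inhibition of Dihydrofolate reductase (Gallus gallus) (on this read-out higher numbers stand for weaker inhibition and lower numbers for stronger inhibition), compound 1 gives 29500 nM
- compound 2, `CCCCOc1ccccc1Cc1cnc(N)nc1N` — in this assay compound 2 gives 8710 nM
- compound 3, `CCOc1ccccc1Cc1cnc(N)nc1N` — in this assay compound 3 gives 24500 nM

Compound 3 has the second highest of the three numbers; its difference from compound 1 is a 1.2-fold lower number from compound 1 to compound 3 (0.08 log units; within the scatter), which lies within the scatter, while the step of a 2.8-fold higher number from compound 2 to compound 3 (0.45 log units; beyond the scatter) lies beyond it. All three share the same core and differ only in the group on the aromatic ring.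

Compound 4, `Nc1ncc(Cc2ccccc2OCc2ccccc2)c(N)n1`, has not yet been measured. It differs from compound 3 by phenyl in place of methyl on a saturated chain carbon bound to an oxygen on an aromatic ring. Within the data shown here, two measured steps bear on this change, both of which lengthen the group on the aromatic carbon: a 3.4-fold lower number from compound 1 to compound 2 (0.53 log units; beyond the scatter) and, read in reverse, a 2.8-fold higher number from compound 2 to compound 3 (0.45 log units; beyond the scatter). Each time the group grew, the number in this assay dropped by a modest amount beyond the scatter. A larger group entering here is therefore expected to give a modest drop again, a 2.7-fold lower number from compound 3 to compound 4 (0.43 log units; beyond the scatter). The estimate for compound 4 in this assay is 9000 nM, within a range from 2500 nM to 30000 nM.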

Compound 4, inhibition constant: 9120 nM
The estimate for compound 4 lay 1.0-fold (0.01 log units) below the measured number; low and high end bracket the measured number.
By their numbers in this assay, from the lowest: compounds 2 and 4 (each within the scatter of the next); then compounds 3 and 1 (each within the scatter of the next).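

In this assay, the change to a ring-bearing group gives a 2.7-fold lower number from compound 3 to compound 4 (0.43 log units; beyond the scatter), so the gain seen earlier with the longer saturated chain also appears when the group ends in a phenyl ring. Comparing that ring with the open chain gives a 1.0-fold higher number from compound 2 to compound 4 (0.02 log units; within the scatter), which means that phenyl and propyl at this place cannot be told apart in this read-out, even though one brings a six-membered aromatic ring and the other does not. No measurement here explains why either group gives the number it does.

Still open, as far as these compounds go, is how a phenethyl group, a pyridine ring or an amine at the end of the chain would read at this place. The compounds shown also leave open whether any group here can give a clearly lower number than compound 2 and compound 4.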